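Chain Lengthening Across Two Sulfonate Series

The source may report more compounds than this note shows. Statements on the series, on what has been measured and on what is new or still open speak of the compounds shown alone.

Compound 1 `CCCC(=O)Nc1cccc(S(=O)(=O)Oc2ccccc2C(C)C)c1` and compound 2 `CCCCCC(=O)Nc1cccc(S(=O)(=O)Oc2ccccc2C(C)C)c1` share one core; compound 3 `CCCNC(=O)Nc1ccc(S(=O)(=O)Oc2ccccc2C(C)C)cc1` and the not yet measured compound 4 `CCCCCNC(=O)Nc1ccc(S(=O)(=O)Oc2ccccc2C(C)C)cc1` share another, and the difference between the two cores is not broken down here. In a functional assay on HT-1080 cells (Homo sapiens) for antiproliferative activity, read by sulforhodamine B assay, with a stated time of 48 h (a lower number here means a stronger inhibitor, a higher number a weaker inhibitor), compound 1 gives 15000 nM, while compound 2 gives 11000 nM; the change ethyl in place of hydrogen on a saturated chain carbon, three bonds along the chain from a carbonyl carbon gave a 1.4-fold lower number from compound 1 to compound 2 (0.13 log units; within the scatter). In this assay compound 3 gives 680 nM, the lowest of the three numbers and beyond the scatter from both others. Compound 4 carries the same kind of change, (ethyl in place of hydrogen on a saturated chain carbon, three bonds along the chain from an amide-type nitrogen), the place now lying three bonds along the chain from an amide-type nitrogen rather than from a carbonyl carbon. Because the earlier step of a 1.4-fold lower number from compound 1 to compound 2 (0.13 log units; within the scatter) stayed within the scatter, a similarly small step is expected for compound 4, a 1.4-fold lower number from compound 3 to compound 4 (0.13 log units; within the scatter). Compound 4 is therefore estimated at 500 nM, with a likely range from 150 nM to 2000 nM.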

Compound 4, half-maximal inhibitory concentration: 4700 nM
Estimate against measurement, compound 4: 9.4-fold (0.97 log units) below; measured number above the stated range.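

In this assay, putting ethyl in place of hydrogen gave a 6.9-fold higher number from compound 3 to compound 4 (0.84 log units; beyond the scatter), so this change did not carry over unchanged from one core to the other: the same change on two cores in this assay, a 1.4-fold lower number (0.13 log units; within the scatter) from compound 1 to compound 2 and a 6.9-fold higher number (0.84 log units; beyond the scatter) from compound 3 to compound 4, 9.4-fold (0.97 log units) apart, beyond the scatter of two such steps

In this series, then, a small step on one core was a poor guide to the same change on the other. For the compounds shown here, this does not show why the two cores differ, and with only one pair per core, it gives no rule for other changes or other cores.

The compounds shown leave open which difference between the two cores matters. They also leave open how a longer chain, or a chain carrying an amine or a carboxylic acid, would behave on either core.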